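Swapping the pyridine amide on a piperidine benzylamine core

This account rests on a few compounds, and the source may have more. Where it says the series, first, only, none or still open, it means among the compounds named here.

Measured so far:
- compound 1, `CCOc1cc(CN2CCC(NC(=O)c3ccc(N)nc3)CC2)cc(OCC)c1-c1ccc(F)cc1`, 7.86 in a physicochemical assay for acid dissociation, read by spectrophotometry
- compound 2, `CCOc1cc(CN2CCC(NC(=O)c3cncc(C)c3)CC2)ccc1C`, 8.08 in this assay

Compound 2 gives the higher of the two numbers, but compound 1 sits only a little lower, and that gap is within the usual scatter of this assay, so the two cannot be told apart. Compounds 1 and 2 differ in more than one place, so their difference is not a single step.

Compound 3, `CCOc1cc(CN2CCC(NC(=O)c3ccc(N)nc3)CC2)ccc1C`, has not been measured. It differs from compound 2 in one place: 6-aminopyridin-3-yl in place of 5-methylpyridin-3-yl on a carbonyl carbon. The same amide group is already carried by compound 1, and compound 1 gives 7.86, a value within the scatter of compound 2. The step from compound 2 to compound 3 is therefore expected to be small, a number 0.13 log units lower from compound 2 to compound 3 (within the scatter), none beyond the scatter in either direction. Compound 3 is estimated at 7.95, with a range from 7.6 to 8.3.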

Compound 3, acid dissociation constant: 8.27
The estimate for compound 3 lay 0.32 log units below the measured number; measured number inside the range.
By their numbers in this assay, from the lowest: compounds 1, 2 and 3 (each within the scatter of the next, the first and the last beyond it).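

In this assay, among the compounds shown here, putting 6-aminopyridin-3-yl in place of 5-methylpyridin-3-yl on a carbonyl carbon gives a number 0.19 log units higher from compound 2 to compound 3 (within the scatter) and is the first comparison here that changes one place only. At this place, the two groups cannot be told apart in this read-out, even though they differ in their counts of hydrogen-bond donors and acceptors. Nothing measured here bears on why the read-out responds in this way.

Still open, going by these compounds, is whether a different group on the same carbonyl carbon, such as a carboxylic acid or a longer chain, would give a step beyond the scatter. Also open, on these data alone, is whether the change from 5-methylpyridin-3-yl to 6-aminopyridin-3-yl would read the same way on the core of compound 1.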